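A few compounds are considered here, and "the series" means these few. Any claim that something is new, unique, unknown or untested is made for them only; others in the source may bear on it.

Two esters built on one shared core have been measured in an ADME assay on microsomes from liver (Rattus norvegicus, strain Sprague-Dawley) for metabolic stability, read by LC-MS, with a stated time of 15 min, tested at 20 uM; on this read-out higher numbers stand for a more stable compound and lower numbers for a less stable compound. Compound 1 `CCC(C)c1ccccc1OC(=O)c1coc(-c2ccccc2)n1` gives 8.3% in this assay, and compound 2 `Cc1ccc(COC(=O)c2coc(-c3ccccc3)n2)c(C)c1` gives 16.9%. Compound 1 has the lower of the two numbers, but the gap to compound 2 lies within the scatter of this kind of measurement, so the two compounds cannot be told apart on these data; both simply show that only a small share of the material survives the incubation.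

Compound 3 `O=C(Oc1ccccc1)c1coc(-c2ccccc2)n1` has not yet been measured in this assay. It differs from compound 1 in one place: hydrogen in place of sec-butyl on an aromatic carbon. The change sits on an aromatic carbon of a six-membered aromatic ring of carbon only, ortho to a large group.

Within the data shown here, no pair of measured compounds shows what such a change does in this assay, so any expectation rests on the two numbers above. Since both measured compounds give low readings, compound 3 is expected to stay in the same low region, with a step of a number 2.7 percentage points higher from compound 1 to compound 3 (within the scatter) that is not expected to go beyond the scatter in either direction. The estimate for compound 3 in this assay is 11%, with a range from 3% to 30%.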

Compound 3, percent of the compound remaining: 0.2%
Compound 3: middle estimate off by 10.8 percentage points, on the high side, and the stated range ends above it.
By their numbers in this assay, from the lowest: compounds 3, 1 and 2 (each within the scatter of the next, the first and the last beyond it).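

Swapping sec-butyl for hydrogen on the aromatic carbon gives the first pair in this assay that differs in only one place, and it shows a number 8.1 percentage points lower from compound 1 to compound 3 (within the scatter). On this evidence, sec-butyl and hydrogen at this position cannot be told apart, and the low reading does not depend on the sec-butyl group, as compound 3 carries only hydrogen there and gives 0.2%. The data offer no measurement that would explain why so little of compound 3 remains.

Going by these compounds, the two groups compared here are a branched carbon chain and a bare hydrogen, so it remains open whether an amine, a carboxylic acid or a longer chain at this position would shift the reading beyond the scatter. Also unresolved is whether a change elsewhere, such as an amide in place of the ester link found in all three compounds, would lift the number out of the low region that these compounds occupy.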